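This account rests on a few compounds, and the source may have more. Where it says the series, first, only, none or still open, it means among the compounds named here.

In a functional assay on K562 cells (Homo sapiens) for cytotoxicity, read by MTT assay, with a stated time of 72 h (a higher number here means that more compound is tolerated, a lower number that less compound is tolerated), the measured compounds are:

compound 1, `CS/C(=N\C(=O)c1cc2ccccc2s1)NC(=O)c1cc2ccccc2s1`, 98600 nM;
compound 2, `CS/C(=N\C(=O)c1ccco1)NC(=O)c1ccco1`;
compound 3, `O=C(/N=C(/NC(=O)c1ccco1)[Se]Cc1ccccc1)c1ccco1`, 80600 nM.

For compound 2 this assay gives only a limit, > 100000 nM, which is not a number. That limit is the limit of > 100000 nM in this assay, at which 1 of the 3 values shown sits.

Compound 2 and compound 3 share a core and differ by a group of 8 heavy atoms (7 carbon, 1 selenium; one six-membered aromatic ring of carbon only) in place of a group of 2 heavy atoms (1 carbon, 1 sulfur; no ring), on a carbon with a double bond to nitrogen. This change made an at least 1.2-fold lower number from compound 2 to compound 3 (0.09 log units; that floor lies within the scatter), so the two values cannot be told apart with confidence.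

Compound 1 has a different core; the difference between the two cores is not broken down here. Compound 4, `O=C(/N=C(/NC(=O)c1cc2ccccc2s1)[Se]Cc1ccccc1)c1cc2ccccc2s1`, is not yet measured and differs from compound 1 by a group of 8 heavy atoms (7 carbon, 1 selenium; one six-membered aromatic ring of carbon only) in place of a group of 2 heavy atoms (1 carbon, 1 sulfur; no ring), on a carbon with a double bond to nitrogen. The place of the change is the same as in the earlier pair, so it is the same change on another core.

The step from compound 1 to compound 4 is expected to be a 1.2-fold lower number from compound 1 to compound 4 (0.09 log units; within the scatter), because the same change gave an at least 1.2-fold lower number from compound 2 to compound 3 (0.09 log units; that floor lies within the scatter). Compound 4 is therefore expected to give about 80000 nM, most likely between 40000 nM and 160000 nM, with the possibility that this assay again reports only a limit.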

Compound 4, concentration lethal to 50% of the cells: 70600 nM
The estimate for compound 4 lay 1.1-fold (0.05 log units) above the measured number; the range from low to high includes it.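

On the core of compound 1, putting the larger group with selenium and an aromatic ring in place of methylsulfanyl gives a 1.4-fold lower number from compound 1 to compound 4 (0.15 log units; within the scatter) in this assay. Set beside the earlier pair, the change can be compared across the two cores only in part: the same change on two cores in this assay, an at least 1.2-fold lower number (0.09 log units; that floor lies within the scatter) from compound 2 to compound 3 and a 1.4-fold lower number (0.15 log units; within the scatter) from compound 1 to compound 4; the limit leaves it open whether they differ

Going by these compounds, the pairs therefore give no clear sign that the change acts differently on the two cores, but they do not show that it acts alike, and the true size of the step on the core of compound 2 stays unknown.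

The compounds shown leave open whether another group on this same carbon, such as an amine or a longer chain in place of methylsulfanyl, would give a step beyond the scatter. For the compounds shown here, only two cores and two groups at this place appear here, so these results say nothing about how the change would carry over to any other core.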